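Ethynyl for Iodo on a Shared Nucleoside Core

The source may hold more compounds than are shown below. What is called first, only, known or untested is meant among the compounds shown, and "the series" means these compounds.

compound 1, `Nc1nc(N)c2c(-c3ccsc3)cn([C@@H]3O[C@H](CO)[C@@H](O)[C@H]3O)c2n1`: > 20000 nM
compound 2, `Nc1nc(N)c2c(-c3cc4ccccc4o3)cn([C@@H]3O[C@H](CO)[C@@H](O)[C@H]3O)c2n1`: > 20000 nM
compound 3, `COc1ncnc2c1c(I)cn2[C@@H]1O[C@H](CO)[C@@H](O)[C@H]1O`: > 20000 nM

In a functional assay on CEM-DNR-bulk cells (Homo sapiens), read by MTT assay, with a stated time of 72 h (on this read-out lower numbers stand for stronger inhibition and higher numbers for weaker inhibition), each of the three values given is a limit of the assay rather than a number, so every measured compound sits at the limit of > 20000 nM in this assay, at which 3 of the 3 values shown sit. The step that the two limits leave unreadable from compound 1 to compound 2 therefore cannot be read. Compound 3 stands at that same limit, with no numeric value behind it. The unmeasured compound 4, `C#Cc1cn([C@@H]2O[C@H](CO)[C@@H](O)[C@H]2O)c2ncnc(OC)c12`, differs from compound 3 by ethynyl in place of iodo on an aromatic carbon. No measured step involves an ethynyl or an iodo group, so nothing shown bears on this change. The limit seen for compound 3 is expected to carry over, giving an estimated step that the limit leaves unreadable from compound 3 to compound 4. Compound 4 is therefore expected to give about 25000 nM, within 8000 nM to 80000 nM, and most likely again only a limit.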

Compound 4, half-maximal inhibitory concentration: 3490 nM
Estimate against measurement, compound 4: 7.2-fold (0.86 log units) above; the measured number lies below the stated range.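

In this assay, ethynyl in place of iodo on an aromatic carbon of the five-membered ring gives an at least 5.7-fold lower number from compound 3 to compound 4 (0.75 log units; beyond the scatter). The step between compound 1 and compound 2 cannot be read, and the other three compounds shown remain at a limit of the assay: the limit of > 20000 nM in this assay, at which 3 of the 4 values shown sit. So compound 4 gives the first sign that a change at this position can take the number off that limit.

As far as these compounds go, the true size of the step stays open, as does whether a nitrile or a longer alkyne chain would lower the number here. From the compounds shown here alone, it is also open whether ethynyl would do so on the core of compound 1.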